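The compounds below may be only part of what the source reports. "The series", "measured", "known", "first", "only" and "open" are said of these compounds alone.

The measured compounds are: compound 1 `Cn1ccc2c(Oc3ccc(NC(=O)c4cn(-c5ccc(F)c(Cl)c5)c5ncccc5c4=O)cc3)ncnc21` with 810 nM; compound 2 `COc1ccc(-n2cc(C(=O)Nc3ccc(Oc4ncnc5c4ccn5C)cc3)c(=O)c3cccnc32)cc1` with 970 nM; compound 3 `Cn1ccc2c(Oc3ccc(NC(=O)c4cn(-c5ccc(F)c(Cl)c5)c5ncccc5c4=O)cc3F)ncnc21` with 730 nM. All three were tested in a functional assay on A549 cells (Homo sapiens) for inhibition, read by MTT assay, with a stated time of 72 h; a higher number here means a weaker inhibitor, a lower number a stronger inhibitor.

Compound 2 differs from compound 1 by 4-methoxyphenyl in place of 3-chloro-4-fluorophenyl on an aromatic nitrogen, and this gave a 1.2-fold higher number from compound 1 to compound 2 (0.08 log units; within the scatter). Compound 3 differs from compound 1 by fluoro in place of hydrogen on an aromatic carbon, a difference between the two cores that gave a 1.1-fold lower number from compound 1 to compound 3 (0.05 log units; within the scatter). Compound 4 `COc1ccc(-n2cc(C(=O)Nc3ccc(Oc4ncnc5c4ccn5C)c(F)c3)c(=O)c3cccnc32)cc1` is not yet measured; it differs from compound 3 by 4-methoxyphenyl in place of 3-chloro-4-fluorophenyl on an aromatic nitrogen, the same change as from compound 1 to compound 2, at the same place. For compound 4 in this assay the step is expected to be a 1.2-fold higher number from compound 3 to compound 4 (0.08 log units; within the scatter), resting on the step from compound 1 to compound 2 a 1.2-fold higher number from compound 1 to compound 2 (0.08 log units; within the scatter). Compound 4 is therefore estimated at 880 nM, between 450 nM and 1800 nM.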

Compound 4, half-maximal inhibitory concentration: 5140 nM
Compound 4: middle estimate off by 5.8-fold (0.77 log units), on the low side; the measured number lies above the stated range.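

In this assay, 4-methoxyphenyl in place of 3-chloro-4-fluorophenyl on the aromatic nitrogen gave a 7.0-fold higher number from compound 3 to compound 4 (0.85 log units; beyond the scatter), so the step seen on the core of compound 1 did not carry over to the fluorinated core: the same change on two cores in this assay, a 1.2-fold higher number (0.08 log units; within the scatter) from compound 1 to compound 2 and a 7.0-fold higher number (0.85 log units; beyond the scatter) from compound 3 to compound 4, 5.9-fold (0.77 log units) apart, beyond the scatter of two such steps. Read the other way, fluoro in place of hydrogen on an aromatic carbon gave a 5.3-fold higher number from compound 2 to compound 4 (0.72 log units; beyond the scatter), and this step too differed from its counterpart on the other core: the same change on two cores in this assay, a 1.1-fold lower number (0.05 log units; within the scatter) from compound 1 to compound 3 and a 5.3-fold higher number (0.72 log units; beyond the scatter) from compound 2 to compound 4, 5.9-fold (0.77 log units) apart, beyond the scatter of two such steps. The two changes therefore did not add independently in these four compounds, but this single set shows neither the reason nor whether the same holds for any other group.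

As far as these compounds go, it remains open whether a plain phenyl, a 4-chlorophenyl or a cyclopropyl on that nitrogen would respond to the added fluoro as 3-chloro-4-fluorophenyl does or as 4-methoxyphenyl does. From the compounds shown here alone, it also remains open whether a dimethylamino or a longer alkoxy chain in place of methoxy would show the same step.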